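Notes on the step from compound 3 to compound 4

This account rests on a few compounds, and the source may have more. Where it says the series, first, only, none or still open, it means among the compounds named here.

- compound 1 `COc1ccc2nc(C(=O)Nc3ccc(-c4ccccc4)cc3)c(C)c(O)c2c1`: 50600 nM
- compound 2 `Cc1c(C(=O)Nc2ccc(-c3ccccc3)cc2)nc2ccccc2c1O`: 75500 nM
- compound 3 `COc1ccc2nc(C(=O)Nc3ccc(-c4ccccc4)cc3)c(C)c(C(=O)O)c2c1`: > 100000 nM, a limit of the assay

In a functional assay on A-375 cells (Homo sapiens) for antiproliferative activity, read by MTT assay, with a stated time of 24 h (a higher number here means a weaker inhibitor, a lower number a stronger inhibitor), compound 3 has no number, only (the limit of > 100000 nM in this assay, at which 1 of the 3 values shown sits). Compound 4 `Cc1c(C(=O)Nc2ccc(-c3ccccc3)cc2)nc2ccccc2c1C(=O)O` differs from compound 3 by hydrogen in place of methoxy on an aromatic carbon. The same exchange has been measured once, as a 1.5-fold higher number from compound 1 to compound 2 (0.17 log units; within the scatter), which is within the scatter. The entry of the carboxy group in place of hydroxy, an at least 1.9-fold higher number from compound 1 to compound 3 (0.29 log units; that floor lies within the scatter), has a floor that also lies within the scatter. No step beyond the scatter is therefore expected in this assay, and another limit is the likeliest report. For compound 4 the estimate is 130000 nM, with an expected range of 70000 nM to 260000 nM. The expected change is a step that the limit leaves unreadable from compound 3 to compound 4.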

Compound 4, half-maximal inhibitory concentration: > 100000 nM
Compound 4 was reported as a limit; the forecaster's own chance of this, stated with the estimate: 80%; the middle value does not contradict the limit.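

In this assay the entry of carboxy in place of hydroxy now stands on a second core, the one without methoxy, as an at least 1.3-fold higher number from compound 2 to compound 4 (0.12 log units; that floor lies within the scatter). On neither core does the floor of this change go beyond the scatter: the same change on two cores in this assay, an at least 1.9-fold higher number (0.29 log units; that floor lies within the scatter) from compound 1 to compound 3 and an at least 1.3-fold higher number (0.12 log units; that floor lies within the scatter) from compound 2 to compound 4; the limit leaves it open whether they differ. The step from compound 3 to compound 4 cannot be read, so the exchange of methoxy for hydrogen is readable only between compound 1 and compound 2: the limit of > 100000 nM in this assay, at which 2 of the 4 values shown sit.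

Open, on these data alone, is whether an amine in place of hydroxy would give a step beyond the scatter. As far as these compounds go, a longer chain in place of methoxy is equally open.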